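The source may hold more compounds than are shown below. What is called first, only, known or untested is meant among the compounds shown, and "the series" means these compounds.

For the measured compounds named here, in a functional assay on HepG2 cells (Homo sapiens) for antiproliferative activity, read by MTT assay, with a stated time of 48 h (on this read-out higher numbers stand for weaker inhibition and lower numbers for stronger inhibition), compound 1 `COc1ccc(-c2c(Nc3ccc(C)c(O)c3)c3ccc(OC)cc3oc2=O)cc1` gives 22500 nM, while compound 2 `COc1ccc(-c2c(Nc3ccc(C)cc3)c3ccc(OC)cc3oc2=O)cc1` gives 74400 nM, the higher of the two numbers so far. Compound 3 `COc1ccc(-c2c(Nc3cccc(C(F)(F)F)c3)c3ccc(OC)cc3oc2=O)cc1` changes the group on the nitrogen: 3-(trifluoromethyl)phenyl in place of 4-methylphenyl on a nitrogen on an aromatic ring. Going by the values given here, the only measured step, a 3.3-fold higher number from compound 1 to compound 2 (0.52 log units; beyond the scatter), replaces hydroxy with hydrogen on an aromatic carbon. It is modest and does not test this exchange, so it supports no direction for compound 3, and no shift beyond the scatter is expected. The expected step is a 1.2-fold lower number from compound 2 to compound 3 (0.09 log units; within the scatter). Compound 3 is estimated at 60000 nM, with an expected range of 20000 nM to 150000 nM.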

Compound 3, half-maximal inhibitory concentration: 57300 nM
Compound 3: middle estimate off by 1.0-fold (0.02 log units), on the high side; low and high end bracket the measured number.
By their numbers in this assay, from the lowest: compound 1; then compounds 3 and 2 (each within the scatter of the next).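

In this assay, replacing 4-methylphenyl with 3-(trifluoromethyl)phenyl on the nitrogen gives a 1.3-fold lower number from compound 2 to compound 3 (0.11 log units; within the scatter) and does not separate these two aryl groups. The change from 3-hydroxy-4-methylphenyl gives a 2.5-fold higher number from compound 1 to compound 3 (0.41 log units; beyond the scatter), so compound 1 stays apart from both compounds lacking the hydroxy group, though the size of that gap is modest. The data on hand give no reason for either step. Still open, on these data alone, is whether an amine or a carboxylic acid on this aryl ring would lower the number, and whether a longer alkyl chain on the nitrogen would be tolerated in place of the aryl group.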